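Methyl on the ring hydroxy: expected effect on binding

This account rests on a few compounds, and the source may have more. Where it says the series, first, only, none or still open, it means among the compounds named here.

Three compounds built on the shared core have been run in an assay on isolated protein for binding affinity to Alpha-1D adrenergic receptor (Rattus norvegicus), read by radioligand binding; on this read-out higher numbers stand for weaker inhibition and lower numbers for stronger inhibition. Compound 1 `O=S(=O)(Nc1cccc2c1CCCC2c1c[nH]cn1)c1ccc2ccccc2c1` gives 100 nM in this assay. Compound 2 `CC(=O)Nc1cccc2c1CCCC2c1c[nH]cn1` sits at the lower sensitivity edge: in this assay compound 2 gives < 10000 nM, which is a limit of the assay and not a number (the limit of < 10000 nM in this assay, at which 1 of the 3 values shown sits). Compound 3 `CS(=O)(=O)Nc1c(O)ccc2c1CCCC2c1c[nH]cn1` gives 1260 nM in this assay, the higher of the two numbers obtained; the number for compound 1 lies lower, and the gap between them is beyond the scatter of repeat measurements. Among the measured compounds shown here, no two measured compounds differ from each other in only one place, so no measured single-point step is available, and the effect of any one change has to be judged without a direct precedent.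

Compound 4 `COc1ccc2c(c1NS(C)(=O)=O)CCCC2c1c[nH]cn1` differs from compound 3 by methyl in place of hydrogen on an oxygen on an aromatic ring. With nothing measured to anchor this change, the step from compound 3 to compound 4 in this assay is expected to be a 1.2-fold higher number from compound 3 to compound 4 (0.08 log units; within the scatter), that is, no shift beyond the scatter in either direction. On that basis compound 4 is estimated at 1500 nM in this assay, with a plausible range from 400 nM to 6000 nM.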

Compound 4, inhibition constant: 479 nM
Beside the measured number, compound 4's estimate is 3.1-fold (0.50 log units) above it; measured number inside the range.
By their numbers in this assay, from the lowest: compound 1; then compound 4; then compound 3.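

Hydroxy to methoxy on the aromatic ring gives the series its first single-point step: in this assay the reading is a 2.6-fold lower number from compound 3 to compound 4 (0.42 log units; beyond the scatter) and counts as modest. At this position, then, the hydroxy hydrogen is not needed to keep the number at the level of the parent, and the added methyl on the oxygen is tolerated with a gain rather than a loss. This reading rests on a single pair on the shared core, so it describes this oxygen and this change only, and it sets no trend for other positions.

Still open, on these data alone, is whether a longer chain on the same oxygen, such as ethoxy or propoxy, would extend this step or reverse it, and whether an amine or a fluorine in place of the hydroxy would give a comparable number. Nothing measured among the compounds shown bears on why the methyl moves the number in this direction, and one pair cannot separate the contribution of the added methyl from that of the lost hydrogen.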